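Replacing an amide by a sulfonamide: expected stability

This account rests on a few compounds, and the source may have more. Where it says the series, first, only, none or still open, it means among the compounds named here.

Three compounds sharing one core were tested in an ADME assay on microsomes from liver (Mus musculus) for metabolic stability, read by LC-MS, with NADPH named in the record, with a stated time of 60 min, tested at 1 uM, in the absence of a further agent; on this read-out higher numbers stand for a more stable compound and lower numbers for a less stable compound. Compound 1 `CC(=O)N[C@@H]1CCN(c2cc(C)nn3c(-c4ccc(OC(F)(F)F)cc4)c(C)nc23)C1` carries an acetyl group on the amine nitrogen of the saturated ring. In this assay compound 1 gives > 95%, a limit of the assay rather than a number. Compound 2 `COc1ccc(-c2c(C)nc3c(N4CC[C@@H](NC(=O)COc5ccccc5)C4)cc(C)nn23)cc1OC` carries a (phenoxymethyl)carbonyl group there, and in this assay compound 2 gives > 95%, again a limit. Compound 3 `COc1ccc(-c2c(C)nc3c(N4CC[C@@H](NC(=O)Oc5ccc6ccccc6c5)C4)cc(C)nn23)cc1OC` has (naphthalen-2-yl)oxy on the carbonyl carbon in place of phenoxymethyl, and in this assay compound 3 gives > 95%, also a limit. The step that the two limits leave unreadable from compound 2 to compound 3 therefore cannot be read. Compound 2 thus stands at the limit, as do all values shown, which the limit of > 95% in this assay, at which 3 of the 3 values shown sit, records.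

Compound 4 `COc1ccc(-c2c(C)nc3c(N4CC[C@@H](NS(=O)(=O)c5ccccc5)C4)cc(C)nn23)cc1OC` is not yet measured. It differs from compound 2 in one place: phenylsulfonyl in place of (phenoxymethyl)carbonyl on an amine nitrogen. Among the measured compounds shown here, no measured step runs between a carbonyl-linked and a sulfonyl-linked group, so the only guide is that every measured compound sits at the limit. Compound 4 is therefore expected to stay close to that limit, with an estimate of 93% (from 78% to 99%), meaning an expected step of a number at least 2 percentage points lower from compound 2 to compound 4 (that floor lies within the scatter).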

Compound 4, percent of the compound remaining: > 95%
Compound 4 ended at the assay's limit (the forecaster's own chance of this, stated with the estimate: 65%); middle value at least 2 percentage points away from the limit.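

In this assay compound 4 gives > 95% (a limit of the assay). Among the compounds shown here, compound 2 also sits at a limit, so no step from it to compound 4 can be read: the limit of > 95% in this assay, at which 4 of the 4 values shown sit.

On these data alone, whether phenylsulfonyl and (phenoxymethyl)carbonyl differ at all on this read-out stays open, as does which change to these compounds would bring a value off the limit.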